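Chloro to bromo on the arylidene ring of the shared core

This account rests on a few compounds, and the source may have more. Where it says the series, first, only, none or still open, it means among the compounds named here.

Compound 2 `COc1ccc(/C=C2\CCCC3C2=NN(C2=NC(=O)/C(=C/c4ccc(Cl)cc4)S2)C3c2ccc(OC)cc2)cc1` is one of two compounds of the shared core measured in a physicochemical assay for inhibition, read by colorimetric assay, tested at 1 mg/mL; on this read-out lower numbers stand for less inhibition and higher numbers for more inhibition at the one concentration tested (going by the name of the read-out). In this assay compound 2 gives 25.7%. Going by the values given here, its only measured neighbour is compound 1 `COc1ccc(/C=C2\CCCC3C2=NN(C2=NC(=O)/C(=C/c4ccc(OC)c(OC)c4)S2)C3c2ccc(OC)cc2)cc1`, which in this assay gives 19.1%; the step of a number 6.6 percentage points higher from compound 1 to compound 2 (within the scatter) stays inside the scatter, so the two numbers cannot be told apart.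

Compound 3 `COc1ccc(/C=C2\CCCC3C2=NN(C2=NC(=O)/C(=C/c4ccc(Br)cc4)S2)C3c2ccc(OC)cc2)cc1` is not yet measured. It differs from compound 2 in one place: bromo in place of chloro on an aromatic carbon. Among the compounds with values here, no measured step touches a halogen swap of this kind; the single step on record exchanges a 3,4-dimethoxyphenyl for a 4-chlorophenyl and moves the read-out by no more than the scatter. The step to compound 3 is therefore expected to fall within the scatter as well, in no set direction, that is, about a number 0.3 percentage points higher from compound 2 to compound 3 (within the scatter).

Compound 3 is accordingly expected to give roughly 26% in this assay, with a range from 15% to 38%.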

Compound 3, a percentage reported as inhibition, at one concentration (the size of the read-out at that concentration, not a potency): 5.21%
Estimate against measurement, compound 3: 20.8 percentage points above; measured number outside the range, below it.
By their numbers in this assay, from the lowest: compound 3; then compounds 1 and 2 (each within the scatter of the next).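

The aromatic carbon carrying the halogen is more sensitive than the first pair suggested: in this assay, bromo in place of chloro, a swap of one heavy atom for one with no change in ring, hydrogen-bond donors, hydrogen-bond acceptors or charge, gives a number 20.5 percentage points lower from compound 2 to compound 3 (beyond the scatter). The 4-bromophenyl group also separates from the 3,4-dimethoxyphenyl group, with a number 13.9 percentage points lower from compound 1 to compound 3 (beyond the scatter), so an aryl exchange that stayed inside the scatter with 4-chlorophenyl leaves it with 4-bromophenyl. Nothing on hand bears on why this exchange moves the read-out.

Going by these compounds, whether the lower number belongs to bromo alone or continues along the halogens remains open, and fluoro or iodo on the same aromatic carbon would address that. Also open, on these data alone, is whether a group of another kind there, such as an amine or a carboxylic acid, would read closer to compound 2 or to compound 3, and whether the step from chloro to bromo holds at other concentrations, since the read-out comes from one concentration only.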